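The source may hold more compounds than are shown below. What is called first, only, known or untested is meant among the compounds shown, and "the series" means these compounds.

Measured so far:
- compound 1 `CC[C@@H](C)[C@H](NC(=O)c1ccc(C(CC)(CC)c2ccc(OCC(O)C(C)(C)C)c(C)c2)n1CC)C(=O)OC`: 26 nM
- compound 2 `CCn1c(C(=O)NCCN)ccc1C(CC)(CC)c1ccc(OCC(O)C(C)(C)C)c(C)c1`: 10 nM

In an assay on HL-60 cells for agonist activity at vitamin D3 receptor (Homo sapiens), read by microscopy, with a stated time of 96 h (on this read-out lower numbers stand for an effect already at smaller amounts and higher numbers for an effect only at larger amounts of compound), compound 2 gives the lower of the two numbers shown. Within the data shown here, the only step measured is a 2.6-fold lower number from compound 1 to compound 2 (0.41 log units; beyond the scatter), so a smaller group on the amide nitrogen went with a lower number there.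

Compound 3 `CCn1c(C(=O)N(C)CCC#N)ccc1C(CC)(CC)c1ccc(OCC(O)C(C)(C)C)c(C)c1` is not yet measured. It differs from compound 2 by (2-cyanoethyl)(methyl)amino in place of (2-aminoethyl)amino on a carbonyl carbon. The amide nitrogen now carries two substituents and the chain ends in a nitrile instead of an amine.

Among the measured compounds shown here, only the step from compound 1 to compound 2 bears on this, and it concerned a much larger group than either of the groups exchanged here, so it gives little guidance on the present change. Nothing measured shows what a tertiary amide of this kind does in this assay. On that basis the expected step is small: a 1.8-fold higher number from compound 2 to compound 3 (0.26 log units; within the scatter), a slightly higher number that may well stay within the scatter. Compound 3 is therefore estimated at 18 nM, with a range from 6 nM to 60 nM.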

Compound 3, half-maximal effective concentration: 1960 nM
The estimate for compound 3 lay 110-fold (2.04 log units) below the measured number; the measured number lies above the stated range.
By their numbers in this assay, from the lowest: compound 2; then compound 1; then compound 3.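

In this assay, the group on the carbonyl carbon proves able to shift the number far more than the earlier pair suggested, since (2-cyanoethyl)(methyl)amino in place of (2-aminoethyl)amino gives a 200-fold higher number from compound 2 to compound 3 (2.29 log units; beyond the scatter) in one change. The same group in place of the larger (1-(methoxycarbonyl)-2-methylbutyl)amino gives a 75-fold higher number from compound 1 to compound 3 (1.88 log units; beyond the scatter) and so confirms the jump against a second partner: compound 1 and compound 2 both keep the amide hydrogen, and compound 3, the only one without it, also stands alone in carrying a nitrile. The measurements shown offer nothing that accounts for this jump.

The change alters the nitrogen and the chain end together, so the compounds shown leave open which of the two carries the effect. The (2-aminoethyl)(methyl)amino group would keep the amine and add only the methyl, while the (2-cyanoethyl)amino group would keep the amide hydrogen and add only the nitrile, and the two together could separate these contributions.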